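Nitro removal on the anilide ring of thiosemicarbazones

The compounds below may be only part of what the source reports. "The series", "measured", "known", "first", "only" and "open" are said of these compounds alone.

Measured so far:
compound 1 `C/C(=N/NC(=S)Nc1ccccc1)c1ccccn1`: 0.18 nM
compound 2 `C/C(=N/NC(=S)Nc1cccc([N+](=O)[O-])c1)c1ccccn1`: 38 nM
compound 3 `CC(=NNC(=S)Nc1ccccc1[N+](=O)[O-])c1ccccn1`: 5.7 nM

All three were run in a functional assay on MCF7 cells (Homo sapiens) for cytotoxicity, read by MTT assay, with a stated time of 48 h; on this read-out higher numbers stand for weaker inhibition and lower numbers for stronger inhibition. Compound 1 gives 0.18 nM. Compound 2 gives 38 nM, and compound 3 gives 5.7 nM. Compound 2 and compound 3 share the same atoms, joined differently; the difference between the two cores is not broken down here.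

Among the measured compounds shown here, the one change measured in both directions of interest is hydrogen in place of nitro on an aromatic carbon. That step, a 210-fold lower number from compound 2 to compound 1 (2.32 log units; beyond the scatter), is the largest movement in the set.

Compound 4 `CC(=NNC(=S)Nc1ccccc1)c1ccccn1` is not yet measured. It differs from compound 3 by hydrogen in place of nitro on an aromatic carbon. The two place lines are not the same word for word: in the measured pair the hydrogen enters meta to a large group, whereas in compound 4 it enters ortho to a large group, so this is the same kind of change rather than the same change.

For compound 4 the expectation in this assay is a lower number than compound 3. The step of an 11-fold lower number from compound 3 to compound 4 (1.06 log units; beyond the scatter) is expected to be large but short of a 210-fold lower number from compound 2 to compound 1 (2.32 log units; beyond the scatter), because compound 3 gives 5.7 nM and the removal of the nitro group is made from a different place. Compound 4 is estimated at 0.5 nM, with a range from 0.1 nM to 3 nM.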

Compound 4, half-maximal inhibitory concentration: 0.18 nM
Beside the measured number, compound 4's estimate is 2.8-fold (0.44 log units) above it; the range from low to high includes it.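

In this assay, hydrogen in place of nitro on an aromatic carbon again gives a lower number, a 32-fold lower number from compound 3 to compound 4 (1.50 log units; beyond the scatter), so the direction of the change carries from one nitro compound to the other while its size does not: the same change on two cores in this assay, a 210-fold lower number (2.32 log units; beyond the scatter) from compound 2 to compound 1 and a 32-fold lower number (1.50 log units; beyond the scatter) from compound 3 to compound 4, 6.7-fold (0.82 log units) apart, beyond the scatter of two such steps. The two products do not separate, no change at the digits printed from compound 1 to compound 4 (within the scatter), and the one difference drawn between them is a matter of depiction: the fact that one of compounds 1 and 4 is drawn with a defined configuration and the other without, at the place where they differ. The gap between the two steps therefore sits wholly in their starting values, with compound 2 at 38 nM and compound 3 at 5.7 nM, and it shows neither that compound 4 has the double-bond configuration drawn for compound 1 nor that the size of the step would hold on any other core.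

The compounds shown leave open whether an amine or a carboxylic acid on the same aromatic carbon would stay close to compound 4 at 0.18 nM or move towards the nitro compounds. They also leave open whether a longer chain in place of the methyl group on the shared core would change the number at all.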